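A few compounds are considered here, and "the series" means these few. Any claim that something is new, unique, unknown or untested is made for them only; others in the source may bear on it.

In a functional assay on HCT-116 cells (Homo sapiens) for inhibition (on this read-out lower numbers stand for an effect already at smaller amounts and higher numbers for an effect only at larger amounts of compound), compound 1 (`COc1cc(N2CCC(C(=O)N3CCOCC3)CC2)ccc1Nc1nc(NC2CCCCC2)c2nc[nH]c2n1`) gives 130 nM, compound 2 (`CCN(CC)CC1CCN(c2ccc(Nc3nc(NC4CCCCC4)c4nc[nH]c4n3)c(OC)c2)CC1`) gives 55 nM and compound 3 (`COc1cc(N2CCC(CC(=O)N3CCC(N(C)C)C3)CC2)ccc1Nc1nc(NC2CCCCC2)c2nc[nH]c2n1`) gives 97 nM. Compound 3 thus lies within the scatter of both other compounds, shown by a 1.3-fold lower number from compound 1 to compound 3 (0.13 log units; within the scatter) and a 1.8-fold higher number from compound 2 to compound 3 (0.25 log units; within the scatter). Compound 4 (`COc1cc(N2CCC(CC(=O)N3CCCC3)CC2)ccc1Nc1nc(NC2CCCCC2)c2nc[nH]c2n1`) puts hydrogen in place of dimethylamino on a saturated ring carbon. Going by the values given here, no measured step makes this exact change. The nearest evidence is those two steps and the modest 2.4-fold lower number from compound 1 to compound 2 (0.37 log units; beyond the scatter), so only a small move is expected. The expected step in this assay is a 1.4-fold higher number from compound 3 to compound 4 (0.16 log units; within the scatter), not beyond the scatter. Compound 4 is estimated at 140 nM, with an expected range of 65 nM to 300 nM.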

Compound 4, half-maximal effective concentration: 26 nM
Beside the measured number, compound 4's estimate is 5.4-fold (0.73 log units) above it; the whole stated range lies above it.
By their numbers in this assay, from the lowest: compound 4; then compounds 2, 3 and 1 (each within the scatter of the next, the first and the last beyond it).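

Taking dimethylamino off the saturated ring carbon, two ring bonds from the ring nitrogen, gives a 3.7-fold lower number from compound 3 to compound 4 (0.57 log units; beyond the scatter) in this assay, so the effect here does not depend on that amine. The unsubstituted (pyrrolidin-1-yl)carbonyl side chain also stands apart from the other two side chains, with a 2.1-fold lower number from compound 2 to compound 4 (0.33 log units; beyond the scatter) and a 5.0-fold lower number from compound 1 to compound 4 (0.70 log units; beyond the scatter), which leaves compound 4 the lowest of the four. No measurement shown here accounts for these steps. Open, from the compounds shown here alone, is whether a smaller substituent on that ring carbon, such as a hydroxyl or a methyl, keeps this gain or loses it.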